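Adding a second methyl to the amide of compound 2

The compounds below may be only part of what the source reports. "The series", "measured", "known", "first", "only" and "open" are said of these compounds alone.

Measured in a functional assay on HeLa cells (Homo sapiens) for inhibition, with a stated time of 72 h; on this read-out higher numbers stand for weaker inhibition and lower numbers for stronger inhibition:
Compound 1 `CC(C)(C)OC(=O)N[C@@H](CC(=O)O)C(=O)N(Cc1ccccc1)C1(C(=O)NCc2ccccc2)CCN(Cc2ccccc2)CC1`: > 200000 nM (a limit of the assay)
Compound 2 `CNC(=O)C[C@H](NC(=O)OC(C)(C)C)C(=O)N(Cc1ccccc1)C1(C(=O)NCc2ccccc2)CCN(Cc2ccccc2)CC1`: 84000 nM

Compound 1 gives > 200000 nM, which is a limit of the assay and not a number. Among the measured compounds shown here, compound 2, at 84000 nM, therefore holds the only exact value so far.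

The next compound is compound 3 `CN(C)C(=O)C[C@H](NC(=O)OC(C)(C)C)C(=O)N(Cc1ccccc1)C1(C(=O)NCc2ccccc2)CCN(Cc2ccccc2)CC1`. It differs from compound 2 in one place: methyl in place of hydrogen on an amide-type nitrogen. This puts methyl in place of hydrogen on an amide-type nitrogen, so methylamino becomes dimethylamino.

For the measured compounds named here, only one measured step touches this part of the molecule: an at least 2.3-fold lower number from compound 1 to compound 2 (0.37 log units; beyond the scatter), with methylamino in place of hydroxy on a carbonyl carbon. Going by these compounds, that step starts from a limit, so its full size is unknown, and it is a different change from the one made here. It gives no direction for the added methyl.

The expected result in this assay is a 1.1-fold lower number from compound 2 to compound 3 (0.02 log units; within the scatter), with no clear shift beyond the usual scatter. For compound 3 the estimated value is 80000 nM, with an expected range of 30000 nM to 200000 nM.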

Compound 3, half-maximal inhibitory concentration: 68000 nM
Compound 3: the middle estimate sits 1.2-fold (0.07 log units) above what was measured; low and high end bracket the measured number.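

In this assay, methyl in place of hydrogen on the amide-type nitrogen stays inside the usual scatter (a 1.2-fold lower number from compound 2 to compound 3 (0.09 log units; within the scatter)), so in this pair the amide hydrogen is not needed to keep this level of inhibition. The dimethylamino amide also keeps the gain over the carboxylic acid (an at least 2.9-fold lower number from compound 1 to compound 3 (0.46 log units; beyond the scatter)), which means that this gain appears with both methylamino and dimethylamino in place of hydroxy on the carbonyl carbon. Compound 1 stands at a limit of the assay and not at a number, and the true size of this step stays unknown because of that limit: the limit of > 200000 nM in this assay, at which 1 of the 3 values shown sits.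

Compound 3 still needs a high concentration for inhibition (68000 nM), and the amides shown carry only methyl groups on the nitrogen. Going by these compounds, how the plain unsubstituted amide, with amino on the carbonyl carbon, or a longer chain such as ethyl on that nitrogen would compare remains open.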